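The compounds below may be only part of what the source reports. "The series", "measured", "known", "first", "only" and "open" are said of these compounds alone.

Compound 1 `COc1ccc(C(=O)/C=C/c2cc(-c3cc(OC)c(OC)c(OC)c3)n[nH]2)cc1OC` stands lowest of the three numbers in a functional assay on MDA-MB-231 cells (Homo sapiens) for inhibition, read by MTT assay, with a stated time of 48 h (a higher number here means a weaker inhibitor, a lower number a stronger inhibitor), where compound 1 gives 620 nM. Compound 2 `COc1cc(-c2cc(/C=C/C(=O)c3ccccc3)[nH]n2)cc(OC)c1OC` gives 2300 nM and compound 3 `COc1cc(-c2cc(/C=C/C(=O)c3ccc(Cl)cc3)[nH]n2)cc(OC)c1OC` gives 26000 nM; the steps between them are a 3.7-fold higher number from compound 1 to compound 2 (0.57 log units; beyond the scatter), a 42-fold higher number from compound 1 to compound 3 (1.62 log units; beyond the scatter) and an 11-fold higher number from compound 2 to compound 3 (1.05 log units; beyond the scatter). Compound 4 `COc1cc(C(=O)/C=C/c2cc(-c3cc(OC)c(OC)c(OC)c3)n[nH]2)cc(OC)c1OC` differs from compound 1 by methoxy in place of hydrogen on an aromatic carbon. Among the measured compounds shown here, the only measured step touching the same ring is the loss of both methoxy groups, a 3.7-fold higher number from compound 1 to compound 2 (0.57 log units; beyond the scatter), a modest rise; no measured step adds a methoxy group. On that basis a further methoxy group is expected to move this assay little, within the scatter or at most a small fall. The estimate for compound 4 is 500 nM, range 150 nM to 2000 nM, meaning an expected step of a 1.2-fold lower number from compound 1 to compound 4 (0.09 log units; within the scatter).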

Compound 4, half-maximal inhibitory concentration: 700 nM
The estimate for compound 4 lay 1.4-fold (0.15 log units) below the measured number; the range from low to high includes it.
By their numbers in this assay, from the lowest: compounds 1 and 4 (each within the scatter of the next); then compound 2; then compound 3.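

Methoxy in place of hydrogen, ortho to a methoxy group on the 3,4-dimethoxyphenyl ring, gives a 1.1-fold higher number from compound 1 to compound 4 (0.05 log units; within the scatter) in this assay and no readable change. The earlier steps shown here on this ring only removed or replaced its methoxy groups, and each raised the number; this position now proves to accept a further methoxy group with no such rise. No measurement at hand explains this result. Still open, from the compounds shown here alone, is whether this position accepts anything other than methoxy, such as a hydroxyl, an amine or a longer ethoxy chain.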